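A few compounds are considered here, and "the series" means these few. Any claim that something is new, unique, unknown or untested is made for them only; others in the source may bear on it.

In an ADME assay, at pH 3 (a lower number here means that the compound disappears faster, a higher number that the compound lasts longer), compound 1 (`COc1ccnc(C[S+]([O-])c2nc3cc(OCC(F)(F)F)ccc3[nH]2)c1C`) gives 0.0833 h, while compound 2 (`COc1cnc(C[S+]([O-])c2nc3cc(OC(F)(F)C(F)F)ccc3[nH]2)c(C)c1OC`) gives 0.333 h, the higher of the two numbers, with a gap beyond the scatter. Compound 3 (`COc1ccnc(C[S+]([O-])c2nc3cc(OC(F)(F)C(F)F)ccc3[nH]2)c1C`) differs from compound 2 in one place: hydrogen in place of methoxy on an aromatic carbon. For the measured compounds named here, no measured pair shows this change alone. Compound 1 also lacks that methoxy, although its chain differs as well, and it gives 0.0833 h. A shorter half-life is therefore expected. The expected fall is a 2.4-fold lower number from compound 2 to compound 3 (0.38 log units; beyond the scatter), a little beyond the scatter. Compound 3 is estimated at 0.14 h, with a range of 0.07 h to 0.3 h.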

Compound 3, half-life: 0.0833 h
Estimate against measurement, compound 3: 1.7-fold (0.23 log units) above, within the range that was stated.
By their numbers in this assay, from the lowest: compounds 1 and 3 (each within the scatter of the next); then compound 2.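

The methoxy on the aromatic carbon can now be read alone: in this assay, replacing it with hydrogen gives a 4.0-fold lower number from compound 2 to compound 3 (0.60 log units; beyond the scatter) in a single step, so this position affects how long the compound lasts. With that methoxy absent, placing 1,1,2,2-tetrafluoroethyl in place of 2,2,2-trifluoroethyl on the oxygen gives no change at the digits printed from compound 1 to compound 3 (within the scatter) and does not alter the reading. No measurement shown explains the methoxy step. From the compounds shown here alone, whether ethoxy or an amine at this position would match methoxy remains open. So does the effect of the methoxy alongside 2,2,2-trifluoroethyl.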